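Vero cytotoxicity notes: from compound 2 to compound 3

The source may hold more compounds than are shown below. What is called first, only, known or untested is meant among the compounds shown, and "the series" means these compounds.

Compound 1 `COC(=O)c1cc(-c2cccc(NC(=O)c3ccc(/C=C/C(=O)c4cccc(F)c4)cc3)c2)on1` and compound 2 `COC(=O)c1cc(-c2cccc(NC(=O)c3ccc(/C=C/C(=O)c4ccc(C)c(F)c4)cc3)c2)on1` share one core and differ only by methyl in place of hydrogen on an aromatic carbon. In an ADME assay on Vero cells (Chlorocebus sabaeus) for cytotoxicity, read by MTT assay, with a stated time of 72 h (a lower number here means that less compound is tolerated, a higher number that more compound is tolerated), compound 1 reports no number but a limit of the assay, > 40 ug/mL. In this assay compound 2 likewise reports only a limit, > 50 ug/mL. The step that the two limits leave unreadable from compound 1 to compound 2 is therefore of unreadable size, since both values sit at limits the limit of > 40 ug/mL in this assay, at which 1 of the 2 values shown sits, and (the limit of > 50 ug/mL in this assay, at which 1 of the 2 values shown sits). Compound 2 thus stands among the well-tolerated members of the pair, known only as a limit and not as a number.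

Compound 3 `COC(=O)c1cc(-c2cccc(NC(=O)c3ccc(/C=C/C(=O)c4ccc(OC)cc4OC)cc3)c2)on1` differs from compound 2 by 2,4-dimethoxyphenyl in place of 3-fluoro-4-methylphenyl on a carbonyl carbon. Among the compounds with values here, no measured step in this pair covers such an exchange of one aromatic ring for another, and the single step available is unreadable. The expectation for compound 3 rests on compound 2 staying at a limit in this assay. Compound 3 is expected to remain tolerated, with an estimated 60 ug/mL and a range from 25 ug/mL to 150 ug/mL. The expected step that the limit leaves unreadable from compound 2 to compound 3 is thus estimated as none beyond the scatter, though the starting limit leaves the size open.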

Compound 3, half-maximal cytotoxic concentration: > 50 ug/mL
Compound 3: a limit, no number; the forecaster's own chance of this, stated with the estimate: 70%; the middle value is on the limit's open side.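

In this assay compound 3 gives > 50 ug/mL, a limit of the assay and not a number. Within the data shown here, compound 1, compound 2 and compound 3 all carry limits only, and no step among them can be read. Open, from the compounds shown here alone, is where the actual half-maximal cytotoxic concentration of each compound lies, and whether either aromatic ring exchange shifts it.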